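The compounds below may be only part of what the source reports. "The series", "measured", "known", "first", "only" and "open" are said of these compounds alone.

Working notes on the series. In a functional assay on NCI-H520 cells (Homo sapiens) for cytotoxicity (on this read-out higher numbers stand for weaker inhibition of growth and lower numbers for stronger inhibition of growth), compound 1 `COc1ccc(C2=C(c3ccc(SC)cc3)CC3CCCN3C2=O)cc1C` gives 100 nM and compound 2 `CSc1ccc(C2=C(c3ccc(C)c(C)c3)C(=O)N3CCCC3C2)cc1` gives 300 nM while compound 3 `CSc1ccc(C2=C(c3ccc(O)c(O)c3)C(=O)N3CCCC3C2)cc1` gives 60000 nM as the highest number of the three, with its steps from both others beyond the scatter.

Compound 4 `CSc1ccc(C2=C(c3ccc(O)cc3)C(=O)N3CCCC3C2)cc1` differs from compound 3 in one place: hydrogen in place of hydroxy on an aromatic carbon, ortho to a hydroxy group. This turns 3,4-dihydroxyphenyl into 4-hydroxyphenyl, with hydrogen in place of hydroxy on an aromatic carbon as the counted difference.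

Going by the values given here, two measured steps bear on this change. Both a 600-fold higher number from compound 1 to compound 3 (2.78 log units; beyond the scatter) and a 200-fold higher number from compound 2 to compound 3 (2.30 log units; beyond the scatter) are large, and they bring in 3,4-dihydroxyphenyl in place of 4-methoxy-3-methylphenyl and 3,4-dimethylphenyl. By comparison a 3.0-fold higher number from compound 1 to compound 2 (0.48 log units; beyond the scatter) is modest. Among the compounds with values here, no measured compound carries a single hydroxy, so the size of the step remains open.

Compound 4 keeps one hydroxy and loses the other, so a move to a lower number in this assay is expected, beyond the scatter but smaller than the two large steps. The expected step is a 12-fold lower number from compound 3 to compound 4 (1.08 log units; beyond the scatter) on this estimate. Compound 4 is estimated at 5000 nM within an expected range of 800 nM to 30000 nM for now.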

Compound 4, concentration for 50% growth inhibition: > 100000 nM
Compound 4: no number, only a limit (the forecaster's own chance of this, stated with the estimate: 5%); middle value at least 20-fold (1.30 log units) from the limit.
By their numbers in this assay, from the lowest: compound 1; then compound 2; then compound 3. At a limit, above all of these: compound 4.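

In this assay compound 4 gives > 100000 nM, which is a limit of the assay and not a number. Taking away the hydroxy ortho to a hydroxy group does not bring back growth inhibition: the reading is an at least 1.6-fold higher number from compound 3 to compound 4 (0.22 log units; that floor lies within the scatter), while the single hydroxy of 4-hydroxyphenyl still leaves large steps against the two compounds without hydroxy, an at least 330-fold higher number from compound 2 to compound 4 (2.52 log units; beyond the scatter) and an at least 1000-fold higher number from compound 1 to compound 4 (3.00 log units; beyond the scatter), so among the compounds shown, a second hydroxy is not needed for the weak end of the series. The step from compound 3 has only a floor, and that floor says nothing about order beyond the scatter, because the reading stops at the end of the assay's range: the limit of > 100000 nM in this assay, at which 1 of the 4 values shown sits.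

The compounds shown leave open whether 4-hydroxyphenyl and 3,4-dihydroxyphenyl differ at all in this assay, since only that floor separates them. They also leave open how a 4-aminophenyl, 4-fluorophenyl or plain 4-methylphenyl group would read against the 3,4-dimethylphenyl of compound 2, and so whether hydroxy itself or the loss of the second ring substituent sets the weak end.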